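A few compounds are considered here, and "the series" means these few. Any claim that something is new, unique, unknown or untested is made for them only; others in the source may bear on it.

Measured so far in a functional assay on SMMC-7721 cells (Homo sapiens) for inhibition, read by CCK-8 assay, with a stated time of 72 h, tested at 8 uM; a higher number here means more inhibition of growth at the concentration tested, a lower number less inhibition of growth
Compound 1 `COc1ccc(SCc2ccc(C(=O)Nc3ccccc3N)cc2)cc1` gives 80.1%
Compound 2 `Nc1ccccc1NC(=O)c1ccc(CSc2ccc(C(F)(F)F)cn2)cc1` gives 7.57%
Compound 3 `COc1ccc(SCc2ccc(C(=O)Nc3ccccc3N)cc2)cc1OC` gives 78.9%

Compound 1 at 80.1% stands in the upper part of these numbers, level within the scatter with compound 3 at 78.9% and well apart from compound 2 at 7.57% on the same read-out. Compound 4 `Cc1cc(C)cc(SCc2ccc(C(=O)Nc3ccccc3N)cc2)c1` has not yet been measured. Its change from compound 1 is 3,5-dimethylphenyl in place of 4-methoxyphenyl on a sulfur and this replaces the whole group on the sulfur.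

Among the measured compounds shown here, one measured step bears directly on this group: a number 1.2 percentage points lower from compound 1 to compound 3 (within the scatter) and it adds a methoxy rather than removing one. For the measured compounds named here, no measured step shows the loss of the methoxy or the arrival of methyl groups. Going by the values given here, compound 2 at 7.57% shows that a different group on the sulfur can go with a far lower number, but no single step links it to compound 1.

A modest fall in this assay is therefore expected, not clearly beyond the scatter, with more room downward than upward. The expected change is a number 8.1 percentage points lower from compound 1 to compound 4 (within the scatter) in this assay on this estimate. For compound 4 the estimated value is 72% with an expected range from 45% to 85% in this assay when measured.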

Compound 4, percent growth inhibition at one concentration: 85.1%
Compound 4: the middle estimate sits 13.1 percentage points below what was measured; the whole stated range lies below it.
By their numbers in this assay, from the lowest: compound 2; then compounds 3, 1 and 4 (each within the scatter of the next).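

In this assay, 3,5-dimethylphenyl in place of 4-methoxyphenyl on a sulfur gives a number 5 percentage points higher from compound 1 to compound 4 (within the scatter), so the whole group on the sulfur can change while the number stays level within the scatter. The earlier step showed only that a second methoxy could be added; this one shows that a group with no methoxy, no oxygen and no hydrogen-bond acceptor can stand at this place, with the same count of heavy atoms and an aromatic ring of carbon only, without a measured loss of growth inhibition at the concentration tested. No measurement among the data given explains this result or says which feature of either group matters.

Still open is what separates the low value of compound 2 at 7.57% from the high values of the other compounds, as the single steps shown do not reach its group on the sulfur, which carries a trifluoromethyl. Also open, as far as these compounds go, is how far the tolerance at this place extends, for instance to a phenyl carrying a carboxylic acid or an amine, or to a longer chain on the sulfur in place of the aromatic ring.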